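Aryl swap on the shared core: notes toward compound 4

The source may report more compounds than this note shows. Statements on the series, on what has been measured and on what is new or still open speak of the compounds shown alone.

Measured compounds:
compound 1, `COC(=O)c1sc2cc(-c3ccc(F)nc3)cnc2c1N`, in a functional assay on MCF7 cells (Homo sapiens) for inhibition, read by sulforhodamine B assay, with a stated time of 48 h; a lower number here means a stronger inhibitor of growth, a higher number a weaker inhibitor of growth: "not determined" (no result reported)
compound 2, `COC(=O)c1sc2cc(-c3ccc4ncccc4c3)cnc2c1N`: > 150000 nM
compound 3, `COC(=O)c1sc2cc(-c3cc(OC)cc(OC)c3)cnc2c1N`: 56600 nM

Compound 1 has no number of its own in this assay; its entry reads "not determined" (no result reported), so it cannot be placed against the others. Within the data shown here, of the two values that exist, the one for compound 2 is a limit of the assay, not a number; the limit of > 150000 nM in this assay, at which 1 of the 3 values shown sits, describes that limit. Compound 3 gives 56600 nM and is the only numeric result in the set. Everything measured so far sits at weak growth inhibition.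

The unmeasured compound 4, `COC(=O)c1sc2cc(-c3ccc(N)cc3)cnc2c1N`, differs from compound 1 in one place: 4-aminophenyl in place of 6-fluoropyridin-3-yl on an aromatic carbon. Among the measured compounds shown here, no measured pair shares this change, so no step size can be read from the data. Given that the two known results lie at weak inhibition, the expectation for compound 4 is a value in that same region, with no shift beyond the scatter that could be argued from the numbers shown. Compound 4 is therefore estimated at 60000 nM, with a plausible range from 15000 nM to 150000 nM, and a real chance that only a limit is reported.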

Compound 4, concentration for 50% growth inhibition: 108000 nM
For compound 4 the middle estimate is 1.8-fold (0.26 log units) below the measured one; the range from low to high includes it.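

No new step can be read for compound 4: in this assay compound 1 gives "not determined" (no result reported), and nothing shown accounts for the result. The compounds shown leave open how 4-aminophenyl compares with 6-fluoropyridin-3-yl on the shared core, and whether any aryl group there gives stronger growth inhibition.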